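The source may report more compounds than this note shows. Statements on the series, on what has been measured and on what is new or still open speak of the compounds shown alone.

Series built on the shared core of compound 1 `O=C(O)c1cccc(NC(=O)c2cccc(-c3ccccc3)c2)c1`, which in an assay on isolated protein for agonist activity at Bile acid receptor (Homo sapiens), read by TR-FRET, with a stated time of 3 h, in the absence of a further agent (a lower number here means that less compound is needed, a higher number that more compound is needed for the effect), gives 25 nM. Compound 2 `CCCCOc1cccc(-c2cccc(C(=O)Nc3cccc(C(=O)O)c3)c2)c1` gives 256 nM in this assay, and compound 3 `O=C(O)c1cccc(NC(=O)c2cccc(-c3cccc(OCc4ccccc4)c3)c2)c1` gives 189 nM in this assay. Compound 3 thus holds the second highest of the three numbers: the nearest step is a 1.4-fold lower number from compound 2 to compound 3 (0.13 log units; within the scatter), within the scatter, while the furthest is a 7.6-fold higher number from compound 1 to compound 3 (0.88 log units; beyond the scatter), with the matching step a 10-fold higher number from compound 1 to compound 2 (1.01 log units; beyond the scatter) of similar size.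

Compound 4 `O=C(O)c1cccc(NC(=O)c2cccc(-c3cccc(OCCc4ccccc4)c3)c2)c1` differs from compound 3 by benzyl in place of phenyl on a saturated chain carbon bound to an oxygen on an aromatic ring. Among the compounds with values here, the only measured step at the same place is a 1.4-fold lower number from compound 2 to compound 3 (0.13 log units; within the scatter): phenyl in place of propyl there left the number essentially unchanged, whereas both steps from compound 1 show that either measured group on that aromatic carbon raises the number. Going from benzyloxy to phenethyloxy is therefore expected to change little, and the expected step is a 1.1-fold higher number from compound 3 to compound 4 (0.02 log units; within the scatter), not beyond the scatter. Compound 4 is expected to give 200 nM, within 80 nM to 500 nM.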

Compound 4, half-maximal effective concentration: 169 nM
The estimate for compound 4 lay 1.2-fold (0.07 log units) above the measured number; the range from low to high includes it.
By their numbers in this assay, from the lowest: compound 1; then compounds 4, 3 and 2 (each within the scatter of the next).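

In this assay, benzyl in place of phenyl gives a 1.1-fold lower number from compound 3 to compound 4 (0.05 log units; within the scatter) and so does not separate the two compounds at this saturated chain carbon bound to an oxygen on an aromatic ring. The phenethyloxy and butoxy groups also stand together, with a 1.5-fold lower number from compound 2 to compound 4 (0.18 log units; within the scatter) for phenyl in place of ethyl on the chain, so the three ether groups shown lie within the scatter of one another. The step of a 6.8-fold higher number from compound 1 to compound 4 (0.83 log units; beyond the scatter) makes phenethyloxy a third group, after butoxy and benzyloxy, whose number lies beyond the scatter from compound 1.

No supporting data bear on a cause for these numbers. From the compounds shown here alone, whether methoxy on that aromatic carbon, or an ether chain carrying an amine or a carboxylic acid, would fall in the same range remains open.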